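Benzyl ring substituents in a shared aryloxyethylamine series

The source may hold more compounds than are shown below. What is called first, only, known or untested is meant among the compounds shown, and "the series" means these compounds.

The compounds share one core and differ only on the benzyl ring. Compound 1 `COc1cccc(OC)c1OCCNCCOc1ccccc1OCc1ccccc1` carries hydrogen at the varied carbon and in an assay on CHO cells for displacement of a labelled ligand from Alpha-1B adrenergic receptor (Homo sapiens) (on this read-out higher numbers stand for weaker inhibition and lower numbers for stronger inhibition), gives 0.537 nM. Compound 2 `COc1cccc(OC)c1OCCNCCOc1ccccc1OCc1ccccc1Cl` carries chloro there and in this assay gives 0.562 nM. Among the compounds with values here, compound 3 `COc1cccc(OC)c1OCCNCCOc1ccccc1OCc1ccccc1[N+](=O)[O-]` carries nitro and in this assay gives 2.51 nM, the highest of the three numbers so far. Two measured steps end at the nitro compound, a 4.7-fold higher number from compound 1 to compound 3 (0.67 log units; beyond the scatter) and a 4.5-fold higher number from compound 2 to compound 3 (0.65 log units; beyond the scatter), both beyond the scatter, whereas a 1.0-fold higher number from compound 1 to compound 2 (0.02 log units; within the scatter) stays within it.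

Compound 4 `COc1ccccc1COc1ccccc1OCCNCCOc1c(OC)cccc1OC` has not been measured. It differs from compound 3 by methoxy in place of nitro on an aromatic carbon. Within the data shown here, no measured step involves methoxy, so the change can only be read indirectly. Among the measured compounds shown here, the steps that bear on it are a 4.7-fold higher number from compound 1 to compound 3 (0.67 log units; beyond the scatter) and a 4.5-fold higher number from compound 2 to compound 3 (0.65 log units; beyond the scatter): both are modest rises of similar size, and they show that nitro at this place stands apart from hydrogen and from chloro, which sit close together. Taking nitro away is therefore expected to undo most of that rise, giving a lower number in this assay, estimated as a 3.6-fold lower number from compound 3 to compound 4 (0.55 log units; beyond the scatter). For compound 4 the expected value is 0.7 nM, with a range from 0.3 nM to 1.8 nM.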

Compound 4, inhibition constant: 6.31 nM
Beside the measured number, compound 4's estimate is 9.0-fold (0.95 log units) below it; measured number outside the range, above it.
By their numbers in this assay, from the lowest: compounds 1 and 2 (each within the scatter of the next); then compound 3; then compound 4.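

In this assay, methoxy on this aromatic carbon, ortho to a large group, gives the highest number of the four, with a further rise over the nitro compound (a 2.5-fold higher number from compound 3 to compound 4 (0.40 log units; beyond the scatter)) and larger steps from the chloro compound (an 11-fold higher number from compound 2 to compound 4 (1.05 log units; beyond the scatter)) and the unsubstituted compound (a 12-fold higher number from compound 1 to compound 4 (1.07 log units; beyond the scatter)). Nitro is therefore no longer the lone outlier at this place: hydrogen and chloro remain together at the low end, while both oxygen-bearing groups give higher numbers, and methoxy, with fewer heavy atoms and fewer hydrogen-bond acceptors than nitro, gives the higher number of the two, so neither count orders this pair. Nothing at hand explains this order.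

The compounds shown leave open whether the rise seen with methoxy continues with a longer chain such as ethoxy, and whether a hydroxyl, an amine or a carboxylic acid on this carbon would sit with hydrogen and chloro or with nitro and methoxy. They also leave open whether these groups would keep the same order on another carbon of the benzyl ring.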